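From a Hydroxyethyl Chain to a Methylcarbamoyl Group

The compounds below may be only part of what the source reports. "The series", "measured", "known", "first", "only" and "open" are said of these compounds alone.

Three measured compounds share one core and differ only in the group on the saturated ring. Compound 1 `O=S1(=O)Cc2nc(-c3cc(F)c(Cl)cc3F)nc(N3CCC(CO)CC3)c2C1` gives 3.9 nM in a functional assay on HEK293 cells for agonist activity at Glucose-dependent insulinotropic receptor (Homo sapiens), read by reporter gene assay and cAMP accumulation, with a stated time of 6 h; a higher number here means that more compound is needed for the effect, a lower number that less compound is needed. Compound 2 `O=S1(=O)Cc2nc(-c3cc(F)c(Cl)cc3F)nc(N3CCC(O)CC3)c2C1` gives 14 nM, and compound 3 `O=S1(=O)Cc2nc(-c3cc(F)c(Cl)cc3F)nc(N3CCC(CCO)CC3)c2C1` gives 2.8 nM, the lowest of the three numbers; its gap to compound 1 lies within the scatter, while a 5.0-fold lower number from compound 2 to compound 3 (0.70 log units; beyond the scatter) stands beyond it. Compound 4 `CNC(=O)C1CCN(c2nc(-c3cc(F)c(Cl)cc3F)nc3c2CS(=O)(=O)C3)CC1` carries methylcarbamoyl in place of 2-hydroxyethyl on a saturated ring carbon. The measured steps, a 3.6-fold higher number from compound 1 to compound 2 (0.56 log units; beyond the scatter) and a 1.4-fold lower number from compound 1 to compound 3 (0.14 log units; within the scatter), compare only hydroxy, hydroxymethyl and 2-hydroxyethyl groups; none introduces an amide, so they guide the new step only loosely. A modest rise in the number for compound 4 is expected, a 2.9-fold higher number from compound 3 to compound 4 (0.46 log units; beyond the scatter). Compound 4 is therefore estimated at 8 nM, with a range from 3 nM to 25 nM.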

Compound 4, effective concentration (reported as EC, without a stated level of effect): 51 nM
Beside the measured number, compound 4's estimate is 6.4-fold (0.80 log units) below it; the whole stated range lies below it.
By their numbers in this assay, from the lowest: compounds 3 and 1 (each within the scatter of the next); then compound 2; then compound 4.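

Among the groups shown at this ring carbon, methylcarbamoyl stands apart from the alcohols: an 18-fold higher number from compound 3 to compound 4 (1.26 log units; beyond the scatter) and a 13-fold higher number from compound 1 to compound 4 (1.12 log units; beyond the scatter) are both large, and even a 3.6-fold higher number from compound 2 to compound 4 (0.56 log units; beyond the scatter) is beyond the scatter. The count of hydrogen-bond donors and acceptors stays the same from compound 3 to compound 4, so that count alone does not follow the number here. Nothing measured here accounts for the rise. Still open, going by these compounds, is whether the whole amide or only its methyl matters. A primary carbamoyl group, a dimethylcarbamoyl group or a carboxylic acid at this ring carbon would help separate these.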